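This account rests on a few compounds, and the source may have more. Where it says the series, first, only, none or still open, it means among the compounds named here.

Compound 3 `O=[N+]([O-])c1c[nH]c(-c2nnc(-c3cc(-c4ccccc4)nc4ccc(Cl)cc34)o2)c1` gives 281000 nM in an ADME assay on Vero cells (Chlorocebus sabaeus) for cytotoxicity, read by MTT assay, with a stated time of 72 h (on this read-out lower numbers stand for stronger inhibition and higher numbers for weaker inhibition), and compound 2 `Cn1cc([N+](=O)[O-])cc1-c1nnc(-c2cc(-c3ccccc3)nc3ccc(Cl)cc23)o1` gives 328000 nM. The change between them, (methyl in place of hydrogen on an aromatic nitrogen), gives the step of a 1.2-fold higher number from compound 3 to compound 2 (0.07 log units; within the scatter). Compound 1 `O=[N+]([O-])c1c[nH]c(-c2nnc(Cc3ccccc3F)o2)c1` has a different core; how the core of compound 1 and the core of compound 3 differ is not broken down here. In this assay compound 1 gives 620000 nM. Compound 4 `Cn1cc([N+](=O)[O-])cc1-c1nnc(Cc2ccccc2F)o1` has not yet been measured; it differs from compound 1 by methyl in place of hydrogen on an aromatic nitrogen, the same change as from compound 3 to compound 2. From compound 1 to compound 4 a step of about the same size is expected, a 1.1-fold higher number from compound 1 to compound 4 (0.05 log units; within the scatter), because a 1.2-fold higher number from compound 3 to compound 2 (0.07 log units; within the scatter) stayed within the scatter. Compound 4 is therefore estimated at 700000 nM, between 350000 nM and 1400000 nM.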

Compound 4, half-maximal inhibitory concentration: 245000 nM
Compound 4: middle estimate off by 2.9-fold (0.46 log units), on the high side; the measured number lies below the stated range.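

In this assay, methyl in place of hydrogen on an aromatic nitrogen gives a 2.5-fold lower number from compound 1 to compound 4 (0.40 log units; beyond the scatter), so the step seen on one core did not carry over unchanged to the other: the same change on two cores in this assay, a 1.2-fold higher number (0.07 log units; within the scatter) from compound 3 to compound 2 and a 2.5-fold lower number (0.40 log units; beyond the scatter) from compound 1 to compound 4, 3.0-fold (0.47 log units) apart, beyond the scatter of two such steps. For these two pairs, then, the size of the step differs with the core, and the result on one core was a poor guide to the result on the other. It does not show which part of the cores goes with this gap, and two pairs give no rule for any third core.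

The compounds shown leave open how an ethyl group or a longer chain on that aromatic nitrogen would behave on either core. They also leave open whether either step would hold with a nitrile in place of the nitro group.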